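The source may hold more compounds than are shown below. What is called first, only, known or untested is meant among the compounds shown, and "the series" means these compounds.

Measured so far in a functional assay on MCF7 cells (Homo sapiens) for antiproliferative activity, read by MTT assay, with a stated time of 72 h; a lower number here means a stronger inhibitor, a higher number a weaker inhibitor:
- Compound 1 `c1ccc(COc2ccccc2Nc2ncnc3cc4c(cc23)OCCOCCO4)cc1`: > 100000 nM (a limit of the assay, not a number)
- Compound 2 `FC(F)(F)c1ccc(COc2ccc(Nc3ncnc4cc5c(cc34)OCCOCCOCCOCCO5)cc2)cc1`: 10000 nM
- Compound 3 `O=[N+]([O-])c1ccc(COc2cccc(Nc3ncnc4cc5c(cc34)OCCOCCO5)c2)cc1`: 42400 nM

Compound 2 gives the lower of the two actual numbers, 10000 nM. The nearest neighbour, compound 3, reads 42400 nM, a higher number and beyond the scatter. The third reading is only a limit: the limit of > 100000 nM in this assay, at which 1 of the 3 values shown sits.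

The next compound is compound 4 `c1ccc(COc2ccc(Nc3ncnc4cc5c(cc34)OCCOCCOCCOCCO5)cc2)cc1`, which departs from compound 2 at one place: hydrogen in place of trifluoromethyl on an aromatic carbon. Hydrogen stands in place of trifluoromethyl on an aromatic carbon, para to a large group, so that 4-(trifluoromethyl)benzyl becomes benzyl. Within the data shown here, no measured pair isolates this change, so the expectation is loose.

Among the measured compounds shown here, compound 1, the only measured compound with a plain benzyloxy, reads > 100000 nM, which is a limit. It also differs from compound 4 elsewhere, so it offers only a weak hint. A modest move to a higher number in this assay is expected, probably just beyond the scatter, with the estimated step being a 2.2-fold higher number from compound 2 to compound 4 (0.34 log units; beyond the scatter). The expected value for compound 4 is 22000 nM, within an estimated range of 7000 nM to 70000 nM.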

Compound 4, half-maximal inhibitory concentration: 12000 nM
For compound 4 the middle estimate is 1.8-fold (0.26 log units) above the measured one, and the stated range covers the measured number.
By their numbers in this assay, from the lowest: compounds 2 and 4 (each within the scatter of the next); then compound 3. At a limit, above all of these: compound 1.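

Among these compounds, this is the first pair that isolates this change. In this assay, hydrogen in place of trifluoromethyl on an aromatic carbon, para to a large group, gives no separation between the two compounds (a 1.2-fold higher number from compound 2 to compound 4 (0.08 log units; within the scatter)). At this position, on this core, 4-(trifluoromethyl)benzyl and benzyl therefore cannot be told apart in this read-out, so the trifluoromethyl group is not required to hold the reading of compound 2. Among the compounds shown here, the single limit among the values shown does not bear on this step, and nothing measured here gives a cause for it.

On these data alone, whether the flat result extends to other groups at this place remains open: a methoxy, an amine or a carboxylic acid could keep the reading or move it beyond the scatter. It is also open whether the change between 4-(trifluoromethyl)benzyl and benzyl reads the same on the core of compound 1 or the core of compound 3, since neither of these compounds forms a one-place pair with compound 2 or compound 4, and no step involving them can be read.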